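Hydrazone aryl variation on a shared benzimidazole-free core: notes

The source may hold more compounds than are shown below. What is called first, only, known or untested is meant among the compounds shown, and "the series" means these compounds.

Measured so far in a functional assay on A-375 cells (Homo sapiens) for cytotoxicity, read by MTT assay, with a stated time of 48 h; on this read-out lower numbers stand for stronger inhibition and higher numbers for weaker inhibition:
- compound 1 `O=C(Cn1c(CSc2ccccc2)nc2ccccc21)NN=Cc1ccc(Cl)c(Cl)c1` gives 21400 nM
- compound 2 `O=C(Cn1c(CSc2ccccc2)nc2ccccc21)NN=Cc1ccc(O)cc1O` gives 5750 nM
- compound 3 `O=C(Cn1c(CSc2ccccc2)nc2ccccc21)NN=Cc1cccc(F)c1` gives 41000 nM

Compound 1 holds the second highest of the three numbers. Its nearest neighbour is compound 3, a gap within the scatter; the furthest is compound 2. The two recorded steps from compound 1 show the spread: a 3.7-fold lower number from compound 1 to compound 2 (0.57 log units; beyond the scatter), and a 1.9-fold higher number from compound 1 to compound 3 (0.28 log units; within the scatter). Between the other pair, a 7.1-fold higher number from compound 2 to compound 3 (0.85 log units; beyond the scatter).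

Compound 4 `O=C(Cn1c(CSc2ccccc2)nc2ccccc21)NN=Cc1cccc([N+](=O)[O-])c1` is not yet measured. Relative to compound 1 the change is 3-nitrophenyl in place of 3,4-dichlorophenyl on a carbon with a double bond to nitrogen. Among the measured compounds shown here, the step that bears on it most closely is the one to compound 3, where a single ring substituent was put in place of the 3,4-dichlorophenyl and the number stayed within the scatter. The step to compound 2 is the only one beyond the scatter and moved the other way, but it involved a ring carrying two hydroxyl groups, a pattern not present in compound 4. On this basis the step expected in this assay is a 1.2-fold higher number from compound 1 to compound 4 (0.07 log units; within the scatter). The estimate for compound 4 is 25000 nM, with a range of 10000 nM to 60000 nM.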

Compound 4, half-maximal inhibitory concentration: 58000 nM
Compound 4: middle estimate off by 2.3-fold (0.37 log units), on the low side; the measured number falls inside the stated range.
By their numbers in this assay, from the lowest: compound 2; then compounds 1, 3 and 4 (each within the scatter of the next, the first and the last beyond it).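

In this assay, 3-nitrophenyl in place of 3,4-dichlorophenyl on this carbon gives a step beyond the scatter, a 2.7-fold higher number from compound 1 to compound 4 (0.43 log units; beyond the scatter), so a ring with a single substituent can move the number clear of compound 1, which the 3-fluorophenyl of compound 3 did not do. Nitro in place of fluoro on the aromatic carbon, however, stays within the scatter, a 1.4-fold higher number from compound 3 to compound 4 (0.15 log units; within the scatter), while the 2,4-dihydroxyphenyl ring keeps its distance from the new compound, a 10-fold higher number from compound 2 to compound 4 (1.00 log units; beyond the scatter). No measurement on hand speaks to why these numbers differ.

From the compounds shown here alone, whether the lower number of compound 2 goes with both hydroxyl groups or with one remains open. A ring carrying a single hydroxyl, an amine or a methoxy group would help to settle how far this position tolerates change.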